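Replacing the Fluorophenyl Amide Cap of Compound 3

A few compounds are considered here, and "the series" means these few. Any claim that something is new, unique, unknown or untested is made for them only; others in the source may bear on it.

Measured compounds:
compound 1, `C#CCNC1CCc2c(NCc3cccc(Br)c3)cccc21`, 110 nM
compound 2, `C#CCNC1CCc2c(OCCc3cc(NC(C)=O)ccc3Cl)cccc21`, 590 nM
compound 3, `C#CCNC1CCc2c(OCCc3cc(NC(=O)c4ccc(F)cc4)ccc3Cl)cccc21`, 5100 nM

Of the compounds shown here, three have so far been measured in an assay on cells for inhibition of Amine oxidase [flavin-containing] B (Homo sapiens), read by fluorescence and Amplex Red, with stated times of 30 min and 15 min; a higher number here means a weaker inhibitor, a lower number a stronger inhibitor. Compound 3 stands highest of the three numbers. Among the compounds with values here, its nearest neighbour is compound 2, and the only single-point step in the set, an 8.6-fold higher number from compound 2 to compound 3 (0.94 log units; beyond the scatter), separates them. Within the data shown here, no step is recorded between compound 1 and compound 3; the two values simply show that compound 1 gives 110 nM while compound 3 gives 5100 nM.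

The next compound, compound 4, has the structure `C#CCNC1CCc2c(OCCc3cc(NC(=O)CO)ccc3Cl)cccc21`. Its difference from compound 3 is hydroxymethyl in place of 4-fluorophenyl on a carbonyl carbon. Among the measured compounds shown here, the one measured step that bears on this is an 8.6-fold higher number from compound 2 to compound 3 (0.94 log units; beyond the scatter), in which the same amide position grew from methyl to 4-fluorophenyl and the number rose beyond the scatter. Going from 4-fluorophenyl to hydroxymethyl largely reverses that growth, so the number is expected to fall again, most likely back toward the region of compound 2, though the added hydroxyl carries no precedent in this set. The estimated step is a 6.4-fold lower number from compound 3 to compound 4 (0.80 log units; beyond the scatter) in this assay. Compound 4 is therefore expected to give about 800 nM, within a range of 250 nM to 3000 nM.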

Compound 4, half-maximal inhibitory concentration: 270 nM
Compound 4: middle estimate off by 3.0-fold (0.47 log units), on the high side; low and high end bracket the measured number.
By their numbers in this assay, from the lowest: compound 1; then compound 4; then compound 2; then compound 3.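

In this assay, the cap on this carbonyl carbon proves able to move the number in both directions: hydroxymethyl in place of 4-fluorophenyl gives a 19-fold lower number from compound 3 to compound 4 (1.28 log units; beyond the scatter), which more than undoes the rise seen in an 8.6-fold higher number from compound 2 to compound 3 (0.94 log units; beyond the scatter). The result also separates the loss of the aromatic ring from the entry of the hydroxyl, since hydroxy in place of hydrogen on the saturated chain carbon bound to the carbonyl carbon gives a 2.2-fold lower number from compound 2 to compound 4 (0.34 log units; beyond the scatter), a modest step but one beyond the scatter, so the two small caps are not interchangeable here. Nothing measured here accounts for the direction or size of either step.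

The compounds shown leave open whether the hydroxyl's gain depends on its hydrogen, which a methoxymethyl cap would test, and whether an aminomethyl group, a carboxylic acid or a longer hydroxyalkyl chain on the same carbonyl carbon would lower the number further. They also leave open how this amide series relates to compound 1, which differs from compound 4 in more than one place and so allows no direct reading.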